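The compounds below may be only part of what the source reports. "The series", "measured", "known", "first", "only" and "open" are said of these compounds alone.

Measured so far:
compound 1, `CN(C(=O)NC(=O)c1cccc(C(F)(F)F)c1)c1nc(C(F)(F)F)c(C(=O)N/N=C/c2cccc(C(F)(F)F)c2)s1`, gives 5.79 ug/mL in a functional assay on HepG2 cells (Homo sapiens) for inhibition, read by MTT assay, with a stated time of 72 h; a higher number here means a weaker inhibitor, a lower number a stronger inhibitor;
compound 2, `CN(C(=O)NC(=O)c1c(F)cccc1F)c1nc(C(F)(F)F)c(C(=O)N/N=C/c2ccc(C(F)(F)F)cc2)s1`, gives 49.6 ug/mL.

Compound 2 holds the higher of the two numbers, so in this assay it is the weaker inhibitor of the pair; its nearest neighbour is compound 1, whose number is lower by a margin well beyond the usual scatter. Those two compounds differ in more than one place, so no single step can be read between them. Compound 3, `CN(C(=O)NC(=O)c1c(F)cccc1F)c1nc(C(F)(F)F)c(C(=O)N/N=C/c2cccc(C(F)(F)F)c2)s1`, is built from compound 2 by one change: 3-(trifluoromethyl)phenyl in place of 4-(trifluoromethyl)phenyl on a carbon with a double bond to nitrogen. Compound 1 also carries the 3-(trifluoromethyl)phenyl group and shows the lower number, though it differs from compound 2 elsewhere too, so this is only a hint, not a rule. Compound 3 is therefore expected to give a somewhat lower number than compound 2, a step of a 2.5-fold lower number from compound 2 to compound 3 (0.39 log units; beyond the scatter) of modest size, with wide uncertainty. The estimate for compound 3 in this assay is 20 ug/mL, within a range from 6 ug/mL to 60 ug/mL.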

Compound 3, half-maximal inhibitory concentration: 27.9 ug/mL
Estimate against measurement, compound 3: 1.4-fold (0.14 log units) below, within the range that was stated.
By their numbers in this assay, from the lowest: compound 1; then compounds 3 and 2 (each within the scatter of the next).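

Moving the trifluoromethyl group, with 3-(trifluoromethyl)phenyl in place of 4-(trifluoromethyl)phenyl on a carbon with a double bond to nitrogen, gives a 1.8-fold lower number from compound 2 to compound 3 (0.25 log units; within the scatter) in this assay, so this swap has no effect that can be told from assay noise. The change on the carbonyl carbon does reach beyond the scatter: 2,6-difluorophenyl in place of 3-(trifluoromethyl)phenyl gives a 4.8-fold higher number from compound 1 to compound 3 (0.68 log units; beyond the scatter), so the group on the carbonyl carbon matters more here than the swap on the other side. Among the compounds shown here, nothing measured so far explains either step.

Going by these compounds, it remains open whether 3-(trifluoromethyl)phenyl on the carbonyl carbon gives a similar step when 4-(trifluoromethyl)phenyl sits on the other side. The shown compounds also leave open how an unsubstituted phenyl, an amine or a carboxylic acid would fare at either place.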